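Swapping the aryl group: expected effect on cytotoxicity

The source may report more compounds than this note shows. Statements on the series, on what has been measured and on what is new or still open speak of the compounds shown alone.

Compound 1, `C=CC(=O)Nc1cc(Nc2ncc3ncn(-c4ccc(C)cc4)c3n2)c(OC)cc1N(C)CCN(C)C`, gives 9230 nM in an ADME assay on HT-29 cells (Homo sapiens) for cytotoxicity, read by MTT assay, with a stated time of 72 h; on this read-out higher numbers stand for weaker inhibition and lower numbers for stronger inhibition.
Compound 2, `C=CC(=O)Nc1cc(Nc2ncc3ncn(-c4ccccc4F)c3n2)c(OC)cc1N(C)CCN(C)C`, gives 9750 nM in this assay.
Compound 3, `C=CC(=O)Nc1cc(Nc2ncc3ncn(-c4ccccc4Cl)c3n2)c(OC)cc1N(C)CCN(C)C`, gives 11300 nM in this assay.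

Compound 3 sits at the upper end of these three numbers, yet the steps of a 1.2-fold higher number from compound 2 to compound 3 (0.06 log units; within the scatter) and a 1.2-fold higher number from compound 1 to compound 3 (0.09 log units; within the scatter) are both within the scatter, so the three compounds cannot be told apart on this read-out. Compound 4, `C=CC(=O)Nc1cc(Nc2ncc3ncn(-c4ccc(F)c(Cl)c4)c3n2)c(OC)cc1N(C)CCN(C)C`, keeps the shared core and differs from compound 3 only in the aryl group on the ring nitrogen: 3-chloro-4-fluorophenyl in place of 2-chlorophenyl on an aromatic nitrogen. Every measured step bears on this kind of change, since each swaps one aryl group for another at the same place: a 1.1-fold higher number from compound 1 to compound 2 (0.02 log units; within the scatter), a 1.2-fold higher number from compound 1 to compound 3 (0.09 log units; within the scatter) and a 1.2-fold higher number from compound 2 to compound 3 (0.06 log units; within the scatter), none of them beyond the scatter. Compound 4 is therefore expected to show no step beyond the scatter, a 1.1-fold lower number from compound 3 to compound 4 (0.03 log units; within the scatter). The estimate for compound 4 in this assay is 10500 nM, with a likely range from 5000 nM to 22000 nM.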

Compound 4, half-maximal inhibitory concentration: 1610 nM
Compound 4: the middle estimate sits 6.5-fold (0.81 log units) above what was measured; measured number outside the range, below it.
By their numbers in this assay, from the lowest: compound 4; then compounds 1, 2 and 3 (each within the scatter of the next).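

The aryl group on the ring nitrogen is not a silent place in this assay: the earlier aryl groups could not be told apart, yet 3-chloro-4-fluorophenyl gives a 7.0-fold lower number from compound 3 to compound 4 (0.85 log units; beyond the scatter), together with a 6.1-fold lower number from compound 2 to compound 4 (0.78 log units; beyond the scatter) and a 5.7-fold lower number from compound 1 to compound 4 (0.76 log units; beyond the scatter), all beyond the scatter. Compound 4 therefore has the lowest number of the four, and it alone carries both chloro and fluoro on this aryl group, so the read-out can respond to a change here even though the earlier swaps moved it by no more than the scatter. Nothing available explains why this change has such an effect.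

The compounds shown do not separate the contributions of the two halogens, as no aryl group here carries fluoro and chloro apart in this arrangement. As far as these compounds go, how an unsubstituted phenyl, or a phenyl bearing an amine or a carboxylic acid, would behave at this place also remains open.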